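Swapping the fluoro-bearing acid for a methyl-bearing acid

The source may report more compounds than this note shows. Statements on the series, on what has been measured and on what is new or still open speak of the compounds shown alone.

Measured compounds:
compound 1 `Cc1c(OCCCCOc2ccc(C(=O)O)cc2F)ccc(C(=O)CC2CCCC2)c1O`: 639 nM
compound 2 `Cc1c(OCCCCOc2ccc(C(=O)O)cc2F)ccc(C(=O)CC(C)C)c1O`: 102 nM
compound 3 `CC(=O)c1ccc(OCCCCOc2ccc(C(=O)O)cc2C)c(C)c1O`: 50 nM

In an assay on HEK293 cells for positive allosteric modulation of metabotropic glutamate receptor 2 (Rattus norvegicus), read by thallium flux, with a stated time of 2.5 min (a higher number here means that more compound is needed for the effect, a lower number that less compound is needed), compound 1 needs the most compound of these three, with compound 2 nearest and compound 3 furthest from it. Compound 4 `Cc1cc(OCCCCOc2ccc(C(=O)CC3CCCC3)c(O)c2C)ccc1C(=O)O` is compound 1 with the change (4-carboxy-3-methylphenyl in place of 4-carboxy-2-fluorophenyl on an oxygen on a saturated carbon). Among the measured compounds shown here, the only measured step, a 6.3-fold lower number from compound 1 to compound 2 (0.80 log units; beyond the scatter), concerns the saturated chain carbon bound to the carbonyl carbon, not the aryl acid, so no measured step bears directly on this change. Compound 3 carries the same 4-carboxy-3-methylphenyl group yet also differs at the ketone, so its value alone cannot separate the two effects. A step of a 1.8-fold lower number from compound 1 to compound 4 (0.26 log units; within the scatter) is therefore expected, likely within the scatter; compound 4 is estimated at 350 nM, between 100 nM and 1300 nM.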

Compound 4, half-maximal effective concentration: 564 nM
Compound 4: the middle estimate sits 1.6-fold (0.21 log units) below what was measured, within the range that was stated.
By their numbers in this assay, from the lowest: compound 3; then compound 2; then compounds 4 and 1 (each within the scatter of the next).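

In this assay, replacing 4-carboxy-2-fluorophenyl with 4-carboxy-3-methylphenyl gives a 1.1-fold lower number from compound 1 to compound 4 (0.05 log units; within the scatter), so with the cyclopentyl side chain kept, the two aryl acids cannot be told apart. Among the compounds shown here, the change on the ketone side gives a step beyond the scatter, a 6.3-fold lower number from compound 1 to compound 2 (0.80 log units; beyond the scatter), so of these two changes only that one moves the number measurably. No available evidence explains why the aryl acid swap leaves the number in place.

As far as these compounds go, whether the swap stays as quiet with the isopropyl side chain of compound 2 remains open. From the compounds shown here alone, the effect of a chlorine atom or a methoxy group on the aryl acid also remains unknown.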